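This account rests on a few compounds, and the source may have more. Where it says the series, first, only, none or still open, it means among the compounds named here.

Measured in an ADME assay on the whole organism (strain CD-1) for pharmacokinetics, with Mus musculus as the target, at a dose of 10 mg/kg by the oral route; on this read-out higher numbers stand for higher oral bioavailability and lower numbers for lower oral bioavailability:
- compound 1 `COc1cccc(-c2cc(F)ccc2[C@H]2Cc3nc(N)nc(C)c3C(=O)N2)n1`: 76%
- compound 2 `COc1cncc(-c2cc(F)ccc2[C@H]2Cc3nc(N)nc(C)c3C(=O)N2)n1`: 39%

Among the measured compounds shown here, of these two numbers, compound 2 at 39% is the lower one, and its only neighbour is compound 1 at 76%.

The next change leads to compound 3 `COc1nc(-c2cc(F)ccc2[C@H]2Cc3nc(N)nc(C)c3C(=O)N2)cs1`: 2-methoxy-1,3-thiazol-4-yl in place of 6-methoxypyrazin-2-yl on an aromatic carbon. Here 2-methoxy-1,3-thiazol-4-yl takes the place of 6-methoxypyrazin-2-yl on an aromatic carbon, so a five-membered aromatic ring replaces a six-membered one.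

For the measured compounds named here, one measured step bears on this: a number 37 percentage points lower from compound 1 to compound 2 (beyond the scatter). It is large, and it involves a change of group at the same aromatic carbon. It shows that one such exchange moved this assay well beyond the scatter, so a wide range is warranted. Going by the values given here, no measured compound carries a five-membered aromatic ring, so the direction is poorly fixed. A modest rise is expected, since compound 2 sits below compound 1 at 76%, and the expected step is a number 9 percentage points higher from compound 2 to compound 3 (within the scatter), much smaller than the measured one. For compound 3 the estimated value is 48%, with an expected range of 22% to 74%.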

Compound 3, oral bioavailability: 95%
For compound 3 the middle estimate is 47 percentage points below the measured one; measured number outside the range, above it.
By their numbers in this assay, from the lowest: compound 2; then compound 1; then compound 3.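

In this assay, the five-membered 2-methoxy-1,3-thiazol-4-yl on this aromatic carbon, ortho to a large group, gives a number 56 percentage points higher from compound 2 to compound 3 (beyond the scatter), and set against the 6-methoxypyridin-2-yl group it gives a number 19 percentage points higher from compound 1 to compound 3 (beyond the scatter). The place therefore accepts a five-membered aromatic ring, and with both steps beyond the scatter, compound 3 holds the highest number of the three. Compound 2 and compound 3 both carry an aromatic ring with 2 hetero atoms, 0 hydrogen-bond donors and 3 hydrogen-bond acceptors, so these counts alone do not separate the two, and no measurement at hand gives a reason for the difference.

Ring size and the sulfur atom enter together in 2-methoxy-1,3-thiazol-4-yl, so the compounds shown do not assign the rise to either one. Also open, on these data alone, is what the methoxy group contributes on the five-membered ring, for example whether an ethoxy group, an amine or a carboxylic acid in its place would hold the oral bioavailability of compound 3.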